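The source may hold more compounds than are shown below. What is called first, only, known or untested is meant among the compounds shown, and "the series" means these compounds.

Measured so far:
- compound 1 `Cc1cccc2cc(C(=O)O)cnc12`: > 50 mg/kg
- compound 2 `CCc1cccc2cc(-c3nn[nH]n3)cnc12`: 2.5 mg/kg
- compound 3 `Cc1ccc2cc(-c3nn[nH]n3)cnc2c1C`: 1 mg/kg

In a functional assay on the whole organism (strain Sprague-Dawley) for inhibition, with Rattus norvegicus as the target (on this read-out lower numbers stand for an effect already at smaller amounts and higher numbers for an effect only at larger amounts of compound), compound 1 returns only a limit, (the limit of > 50 mg/kg in this assay, at which 1 of the 3 values shown sits), and no number. Compound 2 gives 2.5 mg/kg in this assay. Compound 3 gives 1 mg/kg and stands lowest of the two numbers shown; its nearest neighbour is compound 2, whose number is higher by a gap beyond the scatter. Going by the values given here, no pair of measured compounds differs in a single place, so no measured step is available, and what follows for compound 4 rests on the structural change alone.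

Compound 4 `Cc1cccc2cc(-c3nn[nH]n3)cnc12` is not yet measured. It differs from compound 3 in one place: hydrogen in place of methyl on an aromatic carbon. The change sits on the carbon ring of the shared core, ortho to a methyl group, meta to a fused ring and para to a fused ring, and the tetrazole common to compounds 2, 3 and 4 is kept.

Expectation: the loss of one methyl is a small change, and a step of modest size towards a higher number, a 2.0-fold higher number from compound 3 to compound 4 (0.30 log units; within the scatter), is expected, though a result within the scatter of compound 3 would not surprise. The estimate for compound 4 in this assay is 2 mg/kg, with a range from 0.7 mg/kg to 6 mg/kg.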

Compound 4, minimum effective dose: < 25 mg/kg
Compound 4 gave a limit, no number; the forecaster's own chance of this, stated with the estimate: 10%; the middle value does not contradict the limit.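

In this assay compound 4 returns < 25 mg/kg, which is a limit and not a number. The steps to compound 4 from compound 3 and from compound 2 therefore cannot be read, so neither hydrogen in place of methyl on the aromatic carbon nor hydrogen in place of methyl on the saturated chain carbon gains a measured size, and the earlier gap between compounds 2 and 3 still cannot be assigned to a single place. Going by these compounds alone, what the result adds is the first single-place comparison of the acid and the tetrazole on the shared core, an at least 2.0-fold lower number from compound 1 to compound 4 (0.30 log units; that floor lies within the scatter), for 2H-tetrazol-5-yl in place of carboxy on an aromatic carbon, although this shows only a floor that lies within the scatter.

The compounds shown leave open how far the number for the methyl-bearing core of compound 4 lies from those of compounds 2 and 3, and so whether the methyl on the carbon ring matters at all. They also leave open what a methoxy group or a chlorine on that aromatic carbon, or a longer chain such as propyl on the core, would give.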